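Phenyl for furan on the piperidine amine side chain

The source may hold more compounds than are shown below. What is called first, only, known or untested is meant among the compounds shown, and "the series" means these compounds.

For the measured compounds named here, compound 2 `c1cc(CNC2CCN(CCCc3c[nH]c4ccc(-n5cnnc5)cc34)CC2)co1` gives the highest of the two numbers so far: in an assay on CHO cells for displacement of a labelled ligand from 5-hydroxytryptamine receptor 1D (Homo sapiens) (a lower number here means a stronger inhibitor, a higher number a weaker inhibitor), compound 2 gives 4.5 nM, while compound 1 `c1ccc(CNCC2CCN(CCCc3c[nH]c4ccc(-n5cnnc5)cc34)CC2)cc1` gives 1.6 nM. Compound 3 `c1ccc(CNC2CCN(CCCc3c[nH]c4ccc(-n5cnnc5)cc34)CC2)cc1` differs from compound 2 by phenyl in place of furan-3-yl on a saturated chain carbon bound to an amine nitrogen. Going by the values given here, only one measured step bears on this, and only in part, since it also moves the amine: a 2.8-fold higher number from compound 1 to compound 2 (0.45 log units; beyond the scatter). The reverse of that step is therefore expected here, a modest fall in this assay, a 2.3-fold lower number from compound 2 to compound 3 (0.35 log units; beyond the scatter). Compound 3 is estimated at 2 nM, within 0.8 nM to 5 nM.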

Compound 3, half-maximal inhibitory concentration: 4.6 nM
For compound 3 the middle estimate is 2.3-fold (0.36 log units) below the measured one, and the stated range covers the measured number.
By their numbers in this assay, from the lowest: compound 1; then compounds 2 and 3 (each within the scatter of the next).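

With the amine held directly on the saturated ring carbon, swapping furan-3-yl for phenyl leaves the result in this assay within the scatter (a 1.0-fold higher number from compound 2 to compound 3 (0.01 log units; within the scatter)). The change from (benzylamino)methyl to benzylamino, with phenyl kept, does go beyond the scatter (a 2.9-fold higher number from compound 1 to compound 3 (0.46 log units; beyond the scatter)), so in these compounds the gap to compound 1 follows the amine's placement and not the aromatic ring. No available evidence accounts for either result. Still open, going by these compounds, is whether a pyridine or cyclohexyl group would also read like phenyl here, and whether (furan-3-yl)methylaminomethyl would match compound 1.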